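Swapping the amino-linked ring: from pyrazole to thiazole

The source may report more compounds than this note shows. Statements on the series, on what has been measured and on what is new or still open speak of the compounds shown alone.

The measured compounds, with their numbers in a functional assay on HCC78 cells (Homo sapiens) for antiproliferative activity, read by MTT assay, with a stated time of 48 h; on this read-out higher numbers stand for weaker inhibition and lower numbers for stronger inhibition:
compound 1 (`CC(Oc1cccnc1Nc1cnn(C)c1)c1cccc(C(=O)NCc2ccc(F)cc2)c1`) gives 68500 nM in this assay;
compound 2 (`CC(Oc1cccnc1Nc1cnn(C)c1)c1cccc(C(=O)NCc2ccc(F)c(Cl)c2)c1`) gives 7800 nM in this assay;
compound 3 (`Cc1ccc(CNC(=O)c2cccc(C(C)Oc3cccnc3Nc3cnn(CC(C)(C)O)c3)c2)cc1`) gives 20500 nM in this assay.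

Compound 3 stands second highest of the three. Compound 2 sits lower than compound 3, and compound 1 sits higher than compound 3, each beyond the usual scatter.

Compound 4 (`Cc1ccc(CNC(=O)c2cccc(C(C)Oc3cccnc3Nc3ncc(C)s3)c2)cc1`) has not yet been measured. It differs from compound 3 in one place: 5-methyl-1,3-thiazol-2-yl in place of 1-(2-hydroxy-2-methylpropyl)-1H-pyrazol-4-yl on a nitrogen on an aromatic ring.

Among the compounds with values here, the only step measured so far, an 8.8-fold lower number from compound 1 to compound 2 (0.94 log units; beyond the scatter), concerns a chloro on the benzylamide ring, a different part of the shared core, and so does not bear on the change from compound 3 to compound 4. Within the data shown here, no measured pair shows what exchanging the ring on the amino nitrogen does. Without guidance, compound 4 is estimated to land near compound 3, with a wide range: a step of a 1.0-fold lower number from compound 3 to compound 4 (0.01 log units; within the scatter) is expected. Compound 4 is therefore estimated at 20000 nM in this assay, between 4000 nM and 100000 nM.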

Compound 4, half-maximal inhibitory concentration: 14800 nM
The estimate for compound 4 lay 1.4-fold (0.13 log units) above the measured number; low and high end bracket the measured number.
By their numbers in this assay, from the lowest: compounds 2, 4 and 3 (each within the scatter of the next, the first and the last beyond it); then compound 1.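

The exchange of the ring on the amino nitrogen gives, in this assay, a 1.4-fold lower number from compound 3 to compound 4 (0.14 log units; within the scatter), the first sign that this position can take a quite different group without a step beyond the scatter. The 1-(2-hydroxy-2-methylpropyl)-1H-pyrazol-4-yl that leaves has 10 heavy atoms and 1 hydrogen-bond donor, while the 5-methyl-1,3-thiazol-2-yl that enters has 6 heavy atoms and 0 hydrogen-bond donors. Nothing measured here explains why so large a swap leaves the two compounds within the scatter of each other.

The ring and its side group change together in this step, so their separate contributions cannot be told apart. The compounds shown also leave open whether an amine or a carboxylic acid on this ring would move the number beyond the scatter.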